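The source may hold more compounds than are shown below. What is called first, only, known or untested is meant among the compounds shown, and "the series" means these compounds.

Of the compounds shown here, three sharing one core have been measured in a functional assay on MGC-803 cells (Homo sapiens) for inhibition, read by MTT assay, with a stated time of 48 h; on this read-out lower numbers stand for stronger inhibition and higher numbers for weaker inhibition. Compound 1 `CCC(=O)N(Cc1ccc(OC)c(O)c1)c1cc(OC)c(OC)c(OC)c1` gives 50 nM. Compound 2 `COc1ccc(CN(C(=O)CCl)c2cc(OC)c(OC)c(OC)c2)cc1O` gives 84 nM. Compound 3 `C=CC(=O)N(Cc1ccc(OC)c(O)c1)c1cc(OC)c(OC)c(OC)c1` gives 62 nM. The number for compound 3 sits between the other two, and all three lie within the usual scatter of one another: a 1.2-fold higher number from compound 1 to compound 3 (0.09 log units; within the scatter), and a 1.4-fold lower number from compound 2 to compound 3 (0.13 log units; within the scatter). The third step, a 1.7-fold higher number from compound 1 to compound 2 (0.23 log units; within the scatter), is also within the scatter.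

Compound 4 `COc1ccc(CN(C(=O)CBr)c2cc(OC)c(OC)c(OC)c2)cc1O` has not yet been measured. It differs from compound 3 in one place: bromomethyl in place of vinyl on a carbonyl carbon. The most relevant measured step is a 1.4-fold lower number from compound 2 to compound 3 (0.13 log units; within the scatter), which swaps one halomethyl group against the vinyl group at the same carbonyl carbon and changes nothing beyond the scatter. Bromomethyl stands close to chloromethyl, so the step from compound 3 to compound 4 is expected to resemble that one in size and, if anything, run the other way. For this assay, compound 4 is therefore expected to give about 75 nM, with a range from 35 nM to 160 nM. The expected step that this estimate implies is a 1.2-fold higher number from compound 3 to compound 4 (0.08 log units; within the scatter), and that expected step is not beyond the scatter.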

Compound 4, half-maximal inhibitory concentration: 140 nM
The estimate for compound 4 lay 1.9-fold (0.27 log units) below the measured number; the measured number falls inside the stated range.
By their numbers in this assay, from the lowest: compounds 1, 3, 2 and 4 (each within the scatter of the next, the first and the last beyond it).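

In this assay, for the compounds shown here, swapping the group on the carbonyl carbon had so far produced no step beyond the scatter, but bromomethyl now does so against vinyl (a 2.3-fold higher number from compound 3 to compound 4 (0.35 log units; beyond the scatter)) and against the ethyl group of compound 1 (a 2.8-fold higher number from compound 1 to compound 4 (0.45 log units; beyond the scatter)), showing that this position can affect the number, although both steps are modest. Exchanging chloro for bromo on the saturated chain carbon gives a step within the scatter (a 1.7-fold higher number from compound 2 to compound 4 (0.22 log units; within the scatter)), so the two halomethyl groups cannot be ranked, and compound 4 cannot be called the weakest of the set. No measurement shown here explains why bromomethyl stands apart from vinyl and ethyl.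

The compounds shown leave open how fluoromethyl, iodomethyl or a longer chain such as butyl would behave on this carbonyl carbon, and whether a group of a different kind, such as an aminomethyl group or a carboxylic acid, would move the number further. They also leave open whether the steps seen here would hold on cells other than MGC-803.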